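Swapping the aryl group on the hydrazone carbon

A few compounds are considered here, and "the series" means these few. Any claim that something is new, unique, unknown or untested is made for them only; others in the source may bear on it.

Two compounds share a core and differ only in the aryl ring attached to a carbon with a double bond to nitrogen. Compound 1 `CN(C)CCn1cnnc1-c1cc(Oc2ccc(NC(=O)N/N=C/c3ccc(O)c(Br)c3)cc2F)ccn1` gives 430 nM in a functional assay on NCI-H460 cells (Homo sapiens) for cytotoxicity, read by MTT assay, with a stated time of 72 h; on this read-out higher numbers stand for weaker inhibition and lower numbers for stronger inhibition. Compound 2 `CN(C)CCn1cnnc1-c1cc(Oc2ccc(NC(=O)N/N=C/c3ccc(F)cc3Cl)cc2F)ccn1` gives 720 nM in this assay, which is the higher of the two numbers, though the change from compound 1 to compound 2 was a 1.7-fold higher number from compound 1 to compound 2 (0.22 log units; within the scatter).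

Compound 3 `CN(C)CCn1cnnc1-c1cc(Oc2ccc(NC(=O)N/N=C/c3cccc(O)c3)cc2F)ccn1` has not yet been measured in this assay. It differs from compound 2 in one place: 3-hydroxyphenyl in place of 2-chloro-4-fluorophenyl on a carbon with a double bond to nitrogen. Going by the values given here, the only measured step that bears on this change is the one from compound 1 to compound 2, a 1.7-fold higher number from compound 1 to compound 2 (0.22 log units; within the scatter), which exchanged one aryl ring for another and moved the number little. A similar exchange back to a hydroxyl-bearing ring is therefore expected to give no step beyond the scatter, a 1.3-fold lower number from compound 2 to compound 3 (0.12 log units; within the scatter). Compound 3 is estimated at 550 nM, with a range from 200 nM to 1500 nM.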

Compound 3, half-maximal inhibitory concentration: 780 nM
Compound 3: the middle estimate sits 1.4-fold (0.15 log units) below what was measured; the measured number falls inside the stated range.
By their numbers in this assay, from the lowest: compounds 1, 2 and 3 (each within the scatter of the next).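

Exchanging 2-chloro-4-fluorophenyl for 3-hydroxyphenyl on the carbon with a double bond to nitrogen gives a 1.1-fold higher number from compound 2 to compound 3 (0.03 log units; within the scatter) in this assay and so makes no readable difference, even though the halogens leave and 1 hydrogen-bond donor and 1 hydrogen-bond acceptor enter. The exchange of 3-bromo-4-hydroxyphenyl for 3-hydroxyphenyl gives a 1.8-fold higher number from compound 1 to compound 3 (0.26 log units; within the scatter) and also stays inside the usual variation, so three differently substituted phenyl rings now cannot be told apart at this position. Nothing available here offers an explanation for this flat result.

Going by these compounds, all three compounds carry a substituted phenyl ring at this place, so the effect of a ring bearing an amine or a carboxylic acid remains open. The same holds for a plain alkyl chain in place of the ring.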